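This account rests on a few compounds, and the source may have more. Where it says the series, first, only, none or still open, it means among the compounds named here.

Working notes on the series.

Compound 3 `CC(C)(C)CC(=O)N1C[C@H](OCC(=O)NC[C@H](NC(=O)C2(C)CCCCC2)C(=O)O)C[C@H]1CNc1ccccn1` gives the lowest number in an assay on a protein complex for inhibition of integrin alpha-5/beta-1 (Homo sapiens), read by ELISA; on this read-out lower numbers stand for stronger inhibition and higher numbers for weaker inhibition: compound 3 gives 1.4 nM. Its nearest neighbour is compound 1 `Cc1cc(C)c(C(=O)N[C@@H](CNC(=O)CO[C@@H]2C[C@@H](CNc3ccccn3)N(C(=O)OCc3ccccc3)C2)C(=O)O)c(C)c1`, which in this assay gives 3.5 nM; furthest is compound 2 `Cc1cc(C)c(S(=O)(=O)N[C@@H](CNC(=O)CO[C@@H]2C[C@@H](CNc3ccccn3)N(C(=O)CC(C)(C)C)C2)C(=O)O)c(C)c1`, which gives 6 nM. Within the data shown here, the one single-change step available, a 4.3-fold lower number from compound 2 to compound 3 (0.63 log units; beyond the scatter), is modest and runs in favour of the (1-methylcyclohexyl)carbonyl amide.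

Compound 4 `Cc1cc(C)c(C(=O)N[C@@H](CNC(=O)CO[C@@H]2C[C@@H](CNc3ccccn3)N(C(=O)CC(C)(C)C)C2)C(=O)O)c(C)c1` differs from compound 3 by 2,4,6-trimethylphenyl in place of 1-methylcyclohexyl on a carbonyl carbon. Among the measured compounds shown here, no measured step covers this exact exchange. Compound 1 carries the same (2,4,6-trimethylphenyl)carbonyl amide as compound 4 but a different acyl group on the ring nitrogen, and its value sits close to that of compound 3; compound 2 shares the ring acyl group of compound 4 but carries a sulfonyl rather than a carbonyl, so neither pair gives a clean read. On that basis the expected step of a 2.1-fold higher number from compound 3 to compound 4 (0.33 log units; beyond the scatter) is a small rise, near the edge of the scatter. Compound 4 is estimated at 3 nM, with a range from 1 nM to 9 nM.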

Compound 4, half-maximal inhibitory concentration: 1.6 nM
For compound 4 the middle estimate is 1.9-fold (0.27 log units) above the measured one; the measured number falls inside the stated range.
By their numbers in this assay, from the lowest: compounds 3 and 4 (each within the scatter of the next); then compounds 1 and 2 (each within the scatter of the next).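

In this assay the exchange of 1-methylcyclohexyl for 2,4,6-trimethylphenyl on a carbonyl carbon, a 1.1-fold higher number from compound 3 to compound 4 (0.06 log units; within the scatter), does not separate the non-aromatic ring from the aromatic one. With the other acyl group held constant, the carbonyl in place of the sulfonyl now has a direct comparison with the aryl group kept as well: a 3.8-fold lower number from compound 2 to compound 4 (0.57 log units; beyond the scatter) runs the same way as a 4.3-fold lower number from compound 2 to compound 3 (0.63 log units; beyond the scatter). A first single-change read also appears at a second place, where neopentyl in place of benzyloxy on a carbonyl carbon gives a 2.2-fold lower number from compound 1 to compound 4 (0.34 log units; beyond the scatter).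

Nothing available accounts for any of these steps. Open, from the compounds shown here alone, is whether a methyl group, as in an acetyl amide, or a pyridine ring on that carbonyl carbon would keep the number as low.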